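Amide aryl swap to thiazole at the weakest benchmark

This account rests on a few compounds, and the source may have more. Where it says the series, first, only, none or still open, it means among the compounds named here.

Measured in an assay on isolated protein for inhibition of Rho-associated protein kinase 1 (Homo sapiens), read by scintillation counting, radiometric assay and 33P incorporation, with a stated time of 40 min, in the presence of a further agent that is not named here; on this read-out higher numbers stand for weaker inhibition and lower numbers for stronger inhibition:
compound 1 `CC(C)(C)c1ccc(C(=O)Nc2cccc(NC(=O)COc3ccc4c(=O)ccoc4c3)c2)cc1` gives 165 nM;
compound 2 `COc1ccc(C(=O)Nc2cccc(NC(=O)COc3ccc4c(=O)ccoc4c3)c2)cc1` gives 18 nM;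
compound 3 `O=C(COc1ccc2c(=O)ccoc2c1)Nc1cccc(NC(=O)c2ccc(OC(F)(F)F)cc2)c1` gives 869 nM.

Compound 3 sits highest of the three on this assay, separated from compound 1 by a 5.3-fold higher number from compound 1 to compound 3 (0.72 log units; beyond the scatter) and from compound 2 by a 48-fold higher number from compound 2 to compound 3 (1.68 log units; beyond the scatter). Compound 4 `Cc1nc(C(=O)Nc2cccc(NC(=O)COc3ccc4c(=O)ccoc4c3)c2)cs1` differs from compound 3 by 2-methyl-1,3-thiazol-4-yl in place of 4-(trifluoromethoxy)phenyl on a carbonyl carbon.

Going by the values given here, no measured step exchanges the aromatic ring itself; all three vary only its substituent, with a 9.2-fold lower number from compound 1 to compound 2 (0.96 log units; beyond the scatter) as the one direction that lowered the number. Among the compounds with values here, the change to compound 4 removes the group that gave the highest number, so a fall in this assay is expected, but its size rests on no direct precedent. Compound 4 is therefore expected at 300 nM (range 60 nM to 1500 nM), an estimated step of a 2.9-fold lower number from compound 3 to compound 4 (0.46 log units; beyond the scatter).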

Compound 4, half-maximal inhibitory concentration: 473 nM
For compound 4 the middle estimate is 1.6-fold (0.20 log units) below the measured one, within the range that was stated.
By their numbers in this assay, from the lowest: compound 2; then compound 1; then compounds 4 and 3 (each within the scatter of the next).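

An exchange of the whole aromatic ring on the carbonyl carbon gives a 1.8-fold lower number from compound 3 to compound 4 (0.26 log units; within the scatter) in this assay, so 2-methyl-1,3-thiazol-4-yl and 4-(trifluoromethoxy)phenyl are not separated on this read-out. The thiazole does not match 4-methoxyphenyl, with a 26-fold higher number from compound 2 to compound 4 (1.42 log units; beyond the scatter), nor 4-(tert-butyl)phenyl, with a 2.9-fold higher number from compound 1 to compound 4 (0.46 log units; beyond the scatter). No available evidence bears on these steps.

Still open, from the compounds shown here alone, is what the methyl group on the thiazole contributes. Also open, going by these compounds, is whether an amine or a carboxylic acid in its place would bring the number closer to that of compound 2.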